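Pyridinylmethyl isomer swap on the chain amine

The compounds below may be only part of what the source reports. "The series", "measured", "known", "first", "only" and "open" are said of these compounds alone.

Compound 2 `c1cncc(CNCCCCN(C[C@H]2Cc3ccccc3CN2)[C@H]2CCCc3cccnc32)c1` carries a (pyridin-3-yl)methyl on the amine at the far end of the chain. In a functional assay on cells for agonist activity at C-X-C chemokine receptor type 4 (Homo sapiens), read by fluorescence and calcium flux, with a stated time of 90 s (on this read-out higher numbers stand for an effect only at larger amounts of compound and lower numbers for an effect already at smaller amounts), compound 2 gives only a limit, > 30000 nM. Compound 1 `c1ccc2c(c1)CN[C@@H](CN(CCCCN(Cc1ccncc1)Cc1ccncc1)[C@H]1CCCc3cccnc31)C2`, which carries a further group on that amine, also gives only a limit, > 30000 nM. Both values sit on (the limit of > 30000 nM in this assay, at which 2 of the 2 values shown sit), so compound 2 stands at the edge of what this assay reports, with no number to rank. Compound 3 `c1ccc2c(c1)CN[C@@H](CN(CCCCNCc1ccncc1)[C@H]1CCCc3cccnc31)C2` differs from compound 2 by pyridin-4-yl in place of pyridin-3-yl on a saturated chain carbon bound to an amine nitrogen. For the measured compounds named here, no measured step covers this change; the expected step is a number no higher from compound 2 to compound 3 (the limit leaves the size open), nothing beyond the scatter. Compound 3 is expected at 30000 nM (10000 nM to 100000 nM), most likely again only a limit.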

Compound 3, half-maximal effective concentration: > 30000 nM
Compound 3 ended at the assay's limit; the forecaster's own chance of this, stated with the estimate: 80%; the middle value sits exactly at the limit.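

No step can be read among compound 1, compound 2 and compound 3 in this assay, as each gives only a limit: the limit of > 30000 nM in this assay, at which 3 of the 3 values shown sit.

Still open, from the compounds shown here alone, is whether pyridin-4-yl in place of pyridin-3-yl, or the further (pyridin-4-yl)methyl on the amine nitrogen, shifts the half-maximal effective concentration at all.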